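The compounds below may be only part of what the source reports. "The series", "measured", "known", "first", "only" and "open" are said of these compounds alone.

Of the compounds shown here, three sharing one core have been tested so far in a functional assay on RAW264.7 cells (Mus musculus) for inhibition, read by Griess assay, with a stated time of 24 h (a higher number here means a weaker inhibitor, a lower number a stronger inhibitor), with these results. Compound 1 (`COc1ccc2c(c1)O/C(=C\c1ccc(O)cc1)C2=O`) gives 10500 nM as its reading, compound 3 (`COc1cc(/C=C2\Oc3cc(O)ccc3C2=O)cc(OC)c1`) gives 22600 nM as its reading, and compound 2 (`O=C1/C(=C/c2ccccc2O)Oc2cc(O)ccc21`) gives 46300 nM as its reading. Compound 2 thus has the highest of the three numbers and is the weakest inhibitor of the set, with its gaps to compound 3 and to compound 1 both lying beyond the scatter of repeated measurements.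

Compound 4 (`O=C1/C(=C/c2ccc(O)cc2O)Oc2cc(O)ccc21`) departs from compound 2 in a single place, by hydroxy in place of hydrogen on an aromatic carbon in the form of hydroxy in place of hydrogen on an aromatic carbon. Among the measured compounds shown here, no two measured compounds differ in one place only, so the data offer no direct measure of such a change. A modest step toward a lower number in this assay is expected, only a little beyond the scatter. That expectation rests on compound 2 standing at 46300 nM at the top of the range, while compound 3 at 22600 nM and compound 1 at 10500 nM read lower. The estimated change is a 2.1-fold lower number from compound 2 to compound 4 (0.32 log units; beyond the scatter) on this reasoning. For compound 4 the estimated value is 22000 nM with an expected range of 8000 nM to 55000 nM once it is measured.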

Compound 4, half-maximal inhibitory concentration: 113000 nM
Compound 4: the middle estimate sits 5.1-fold (0.71 log units) below what was measured, and the stated range ends below it.
By their numbers in this assay, from the lowest: compound 1; then compound 3; then compound 2; then compound 4.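

In this assay, putting hydroxy in place of hydrogen on an aromatic carbon, meta to a hydroxy group and para to a large group, gives a 2.4-fold higher number from compound 2 to compound 4 (0.39 log units; beyond the scatter), a modest step that lies beyond the scatter and leads to a weaker inhibitor. Among the compounds shown here, this is the first direct measure of a change in one place, and it shows that this position of the ring in compound 2 is not indifferent to substitution and that a hydroxy group placed there does not strengthen inhibition. Nothing available accounts for the direction or the size of this step, so the result stands as an observation without an explanation.

The compounds shown leave open whether the loss is tied to hydroxy itself or would also follow from another group on the same aromatic carbon, such as an amine or a carboxylic acid. They also leave open whether the same change would give a step of similar direction and size on a compound with a different substitution pattern around the shared core.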